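The source may hold more compounds than are shown below. What is called first, only, known or untested is meant among the compounds shown, and "the series" means these compounds.

Measured so far in a functional assay on Jurkat cells (Homo sapiens) for inhibition, read by MTT assay, with a stated time of 72 h; on this read-out lower numbers stand for stronger inhibition of growth and higher numbers for weaker inhibition of growth:
Compound 1, `COC(=O)c1nc(C)n(-c2ccc(F)cc2)n1`: 8700 nM
Compound 2, `CCCCc1nc(C(=O)OC)nn1-c1ccc(F)cc1`: only a limit, > 100000 nM

Compound 2 stands at the limit of this assay, (the limit of > 100000 nM in this assay, at which 1 of the 2 values shown sits), so for it no number is known, only that it lies past that point. Compound 3, `COC(=O)c1nc(C2CC2)n(-c2ccc(F)cc2)n1`, differs from compound 2 in one place: cyclopropyl in place of butyl on an aromatic carbon. Within the data shown here, the one measured step that touches this position is an at least 11-fold higher number from compound 1 to compound 2 (1.06 log units; beyond the scatter), where a four-carbon chain entered in place of hydrogen and the number rose past the limit. In compound 3 a smaller group, cyclopropyl, takes the place of butyl, so the step from compound 2 to compound 3 is expected to move back toward the number of compound 1, though with compound 2 known only as a limit its true size cannot be fixed; the expected step is an at least 2.5-fold lower number from compound 2 to compound 3 (0.39 log units; beyond the scatter). For compound 3 the estimate in this assay is 40000 nM, with a range from 12000 nM to 150000 nM.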

Compound 3, concentration for 50% growth inhibition: 9420 nM
Estimate against measurement, compound 3: 4.2-fold (0.63 log units) above; the whole stated range lies above it.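

In this assay, the aromatic carbon between two ring nitrogen atoms accepts a three-membered ring as readily as methyl: cyclopropyl in place of methyl gives a 1.1-fold higher number from compound 1 to compound 3 (0.03 log units; within the scatter). Cyclopropyl in place of butyl gives an at least 10-fold lower number from compound 2 to compound 3 (1.02 log units; beyond the scatter), so among the three compounds shown, the loss of growth inhibition appears with butyl only and does not extend to every group larger than methyl. The true size of that step stays unfixed, since compound 2 is known only as a limit of the assay: the limit of > 100000 nM in this assay, at which 1 of the 3 values shown sits.

The compounds shown leave open where between methyl and butyl the loss sets in, which an ethyl or propyl chain at this place would locate. They also leave open whether a branched isopropyl group, or an amine, fits the cyclopropyl result or the butyl one.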